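A few compounds are considered here, and "the series" means these few. Any claim that something is new, unique, unknown or untested is made for them only; others in the source may bear on it.

Working notes on the series.

Going by the values given here, compound 1 `CCn1c(C(=O)NCCN(C)C)ccc1C(CC)(CC)c1ccc(OCC(=O)C(C)(C)C)c(C)c1` gives 77 nM in an assay on HL-60 cells for agonist activity at vitamin D3 receptor (Homo sapiens), read by microscopy, with a stated time of 96 h (on this read-out lower numbers stand for an effect already at smaller amounts and higher numbers for an effect only at larger amounts of compound), the second highest of the three numbers so far. Compound 2 `CCN(CC)CCCNC(=O)c1ccc(C(CC)(CC)c2ccc(OCC(=O)C(C)(C)C)c(C)c2)n1CC` gives 22 nM and compound 3 `CCn1c(C(=O)N(C)c2ccccc2)ccc1C(CC)(CC)c1ccc(OCC(=O)C(C)(C)C)c(C)c1` gives 18500 nM. The steps among the measured compounds are a 3.5-fold lower number from compound 1 to compound 2 (0.54 log units; beyond the scatter), a 240-fold higher number from compound 1 to compound 3 (2.38 log units; beyond the scatter) and an 840-fold higher number from compound 2 to compound 3 (2.92 log units; beyond the scatter); all three sit on the carbonyl side of the shared core and leave the aryl ether chain untouched.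

Compound 4 `CCn1c(C(=O)NCCN(C)C)ccc1C(CC)(CC)c1ccc(OCC(O)C(C)(C)C)c(C)c1` is not yet measured. It differs from compound 1 by 1-hydroxy-2,2-dimethylpropyl in place of (tert-butyl)carbonyl on a saturated chain carbon bound to an oxygen on an aromatic ring; cut one bond further out, the same difference reads ((tert-butyl)carbonyl)methoxy to 2-hydroxy-3,3-dimethylbutoxy, so one double bond outside aromatic rings leaves and one hydrogen-bond donor enters.

Among the compounds with values here, none of the measured steps bears on this place. Nothing in the series shows how this assay answers a change on the ether chain, so the expectation rests on compound 1 alone and must carry a wide range. The step is expected to be a 2.2-fold lower number from compound 1 to compound 4 (0.34 log units; beyond the scatter), a small shift that could fall either way. Compound 4 is therefore estimated at 35 nM, within a range of 5 nM to 250 nM.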

Compound 4, half-maximal effective concentration: 14 nM
The estimate for compound 4 lay 2.5-fold (0.40 log units) above the measured number; measured number inside the range.
By their numbers in this assay, from the lowest: compounds 4 and 2 (each within the scatter of the next); then compound 1; then compound 3.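

Going by these compounds alone, the ether chain, untouched by the earlier compounds, now proves responsive in this assay: 1-hydroxy-2,2-dimethylpropyl in place of (tert-butyl)carbonyl, on a saturated chain carbon bound to an oxygen on an aromatic ring, gives a 5.5-fold lower number from compound 1 to compound 4 (0.74 log units; beyond the scatter). Within the data shown here, the change keeps the heavy-atom count, removes one double bond outside aromatic rings and adds one hydrogen-bond donor, and this modest step is the first read on this part of the molecule, much smaller than the large step on the carbonyl side, a 240-fold higher number from compound 1 to compound 3 (2.38 log units; beyond the scatter). No measurement here explains the gain in this assay, so the result stands as an observation only.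

The compounds shown leave open whether the step follows the hydroxyl itself or the loss of the carbonyl, a question that a methoxy group, an amine or a plain methylene at the same chain carbon would help to separate. They also leave open whether the same change carries over to the diethylamino side chain of compound 2 or to the methyl(phenyl)amino amide of compound 3, and so whether the step holds beyond the core of compound 1.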